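From methyl to chloro on compound 2

The source may report more compounds than this note shows. Statements on the series, on what has been measured and on what is new or still open speak of the compounds shown alone.

In a physicochemical assay for lipophilicity (on this read-out lower numbers stand for lower lipophilicity and higher numbers for higher lipophilicity), compound 1 (`CCc1ccc(Cc2cc([C@@H]3OC4(CNC4)[C@@H](O)[C@H](O)[C@H]3O)ccc2C)cc1`) gives 3.2 while compound 2 (`COc1ccc(Cc2cc([C@]34OC[C@](CO)(O3)[C@@H](O)[C@H](O)[C@H]4O)ccc2C)cc1`) gives 2.6 and so holds the lower of the two numbers, with a gap beyond the usual scatter of repeated measurements. For the measured compounds named here, these two compounds differ in more than one place, so they offer no single-change step to draw on. Compound 3 (`COc1ccc(Cc2cc([C@]34OC[C@](CO)(O3)[C@@H](O)[C@H](O)[C@H]4O)ccc2Cl)cc1`) has chloro in place of methyl on an aromatic carbon of compound 2, ortho to a 4-methoxybenzyl group and para to a large group (chloro in place of methyl on an aromatic carbon). In this assay, going by the values given here, a small upward step is expected, not beyond the scatter, although no measured step of this kind exists to support it. The estimated step of a number 0.10 log units higher from compound 2 to compound 3 (within the scatter) is therefore modest. For compound 3 the estimated value is 2.7 with an expected range from 2.3 to 3.1 on this scale.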

Compound 3, distribution coefficient: 3.2
For compound 3 the middle estimate is 0.50 log units below the measured one; the measured number lies above the stated range.
By their numbers in this assay, from the lowest: compound 2; then compounds 1 and 3 (each within the scatter of the next).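

In this assay, for the compounds shown here, the exchange of methyl for chloro on the aromatic carbon ortho to a 4-methoxybenzyl group and para to a large group gives a number 0.60 log units higher from compound 2 to compound 3 (beyond the scatter), the first single-change step. It shows that this position responds to a change of one heavy atom, even though the counted hydrogen-bond donors, hydrogen-bond acceptors, rings and net charge of the group stay the same. No measurement shown here bears on why the step has this size.

Still open, on these data alone, is how a fluoro, bromo, nitrile or methoxy group at the same position would compare with methyl and chloro. Also open, as far as these compounds go, is whether the same exchange would give a similar step on the core of compound 1, which carries methyl at the corresponding place.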